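Adding a Second 3-Aminopropyl Arm

The compounds below may be only part of what the source reports. "The series", "measured", "known", "first", "only" and "open" are said of these compounds alone.

Compound 1 `CC(C)=CCC/C(C)=C\CCC(C)=CCNCCCN` and compound 2 `CC(C)=CCC/C(C)=C\CCC(C)=CCNCCCNCCCN` share the same core. In a toxicity assay on CHO cells (Cricetulus griseus) for cytotoxicity, read by WST assay, with a stated time of 24 h (on this read-out higher numbers stand for weaker inhibition and lower numbers for stronger inhibition), compound 1 gives 32100 nM while compound 2 gives 30200 nM on the same read-out, so compound 2 stands level with compound 1, within the usual scatter.

Compound 3 `CC(C)=CCC/C(C)=C\CCC(C)=CCNCCCN(CCCN)CCCN` differs from compound 2 by a single exchange (3-aminopropyl in place of hydrogen on an amine nitrogen): 3-aminopropyl in place of hydrogen on an amine nitrogen, which turns (3-aminopropyl)amino into bis(3-aminopropyl)amino.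

Going by the values given here, the only measured step that bears on this is the same kind of exchange, with a 1.1-fold lower number from compound 1 to compound 2 (0.03 log units; within the scatter) as its size, and it stays within the scatter. One step is thin evidence, and the nitrogen involved here is a different one, so the range has to stay wide.

No step beyond the scatter is therefore expected in this assay for this exchange. The expected step, a 1.1-fold lower number from compound 2 to compound 3 (0.03 log units; within the scatter) by this estimate, is small. For compound 3 the estimated value is 28000 nM within an expected range from 14000 nM to 52000 nM in this measurement.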

Compound 3, half-maximal inhibitory concentration: > 150000 nM
Compound 3 ended at the assay's limit; the forecaster's own chance of this, stated with the estimate: 5%; middle value at least 5.3-fold (0.72 log units) away from the limit.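

In this assay compound 3 gives > 150000 nM, a limit of the assay and not a number: the limit of > 150000 nM in this assay, at which 1 of the 3 values shown sits.

The earlier exchange, with a 1.1-fold lower number from compound 1 to compound 2 (0.03 log units; within the scatter), suggested that adding a 3-aminopropyl arm changes little, but on an amine nitrogen whose other neighbours are saturated chain carbons the same exchange gives an at least 4.9-fold higher number from compound 2 to compound 3 (0.69 log units; beyond the scatter), and turning amino into bis(3-aminopropyl)amino gives an at least 4.6-fold higher number from compound 1 to compound 3 (0.66 log units; beyond the scatter). For these three compounds, then, the effect of this arm depends on which nitrogen carries it, and only the change to bis(3-aminopropyl)amino moves the read-out toward weaker inhibition of the cells beyond the scatter.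

The compounds shown leave open how far past the limit compound 3 really lies, so the true size of both new steps remains unknown. They also leave open whether the end amine of the new arm matters or simply the added chain, a question that a 3-hydroxypropyl group or a plain methyl on the same nitrogen would help to separate.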